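Replacing a ring amine on the shared core with a short hydroxyethyl chain

The compounds below may be only part of what the source reports. "The series", "measured", "known", "first", "only" and "open" are said of these compounds alone.

Of the compounds shown here, three of one urea-linked series have been tested in a functional assay on BaF3 cells (Mus musculus) for inhibition, read by CCK-8 assay, with a stated time of 72 h; on this read-out higher numbers stand for weaker inhibition of growth and lower numbers for stronger inhibition of growth. Compound 1 `Cc1ccc(NC(=O)Nc2ccc(Oc3cc(N4CCNC[C@H]4C)ncn3)cc2)cc1C(F)(F)F` gives 9670 nM and stands highest of the three numbers. Compound 3 `CC(=O)Nc1cc(Oc2ccc(NC(=O)Nc3cc(-n4cnc(C)c4)cc(C(F)(F)F)c3)cc2)ncn1` gives 1320 nM, and compound 2 `CC(=O)Nc1cc(Oc2ccc(NC(=O)Nc3ccc(CN4CCN(C)CC4)c(C(F)(F)F)c3)cc2)ncn1` gives 50 nM; both gaps to compound 1 lie beyond the scatter, so compound 1 is the weakest of the three. Compound 4 `Cc1ccc(NC(=O)Nc2ccc(Oc3cc(NCCO)ncn3)cc2)cc1C(F)(F)F` is not yet measured. It differs from compound 1 in one place: (2-hydroxyethyl)amino in place of 2-methylpiperazin-1-yl on an aromatic carbon. Among the compounds with values here, no measured pair shows this exact change, so the expectation rests on compound 1 alone. The step of a 3.2-fold lower number from compound 1 to compound 4 (0.51 log units; beyond the scatter) is expected to be modest, toward stronger inhibition, and near the edge of the scatter. Compound 4 is estimated at 3000 nM, between 600 nM and 15000 nM.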

Compound 4, concentration for 50% growth inhibition: > 10000 nM
Compound 4 ended at the assay's limit (the forecaster's own chance of this, stated with the estimate: 10%); middle value at least 3.3-fold (0.52 log units) away from the limit.
By their numbers in this assay, from the lowest: compound 2; then compound 3; then compound 1. At a limit, above all of these: compound 4.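

In this assay compound 4 stands at a limit of the assay and not at a number: the limit of > 10000 nM in this assay, at which 1 of the 4 values shown sits.

On this aromatic carbon, (2-hydroxyethyl)amino in place of 2-methylpiperazin-1-yl gives an at least 1.0-fold higher number from compound 1 to compound 4 (0.01 log units; that floor lies within the scatter). This open chain therefore shows no stronger inhibition of growth than the ring of compound 1, and how much weaker it may be cannot be read.

The compounds shown leave open how far compound 4 lies past this limit. They also leave open how a longer chain ending in a dimethylamino group, or a morpholine ring, would read at this position.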